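Pyridinyl for Carboxyphenyl: Expecting a Rise in Bioavailability

The compounds below may be only part of what the source reports. "The series", "measured", "known", "first", "only" and "open" are said of these compounds alone.

Three sulfonamides on a shared core have been measured in an ADME assay on the whole organism for pharmacokinetics, with Homo sapiens as the target; a higher number here means that a larger share of the oral dose reaches the circulation, a lower number that a smaller share of the oral dose reaches the circulation. Compound 1 `O=[N+]([O-])c1cccc(NS(=O)(=O)c2ccc3nc(-c4ccccc4)c(-c4ccccc4)nc3c2)c1` gives 85.6% in this assay. Compound 2 `O=S(=O)(Nc1ccccn1)c1ccc2nc(-c3ccccc3)c(-c3ccccc3)nc2c1` gives 100%. Compound 3 `O=C(O)c1ccccc1NS(=O)(=O)c1ccc2nc(-c3ccccc3)c(-c3ccccc3)nc2c1` gives 83.6%, sitting within the scatter of compound 1 and clearly under compound 2, as the step of a number 16.4 percentage points lower from compound 2 to compound 3 (beyond the scatter) shows; the step of a number 2 percentage points lower from compound 1 to compound 3 (within the scatter) does not leave the scatter.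

Compound 4 `Cc1ccnc(NS(=O)(=O)c2ccc3nc(-c4ccccc4)c(-c4ccccc4)nc3c2)c1` has not yet been measured. It differs from compound 3 by 4-methylpyridin-2-yl in place of 2-carboxyphenyl on a sulfonamide nitrogen, which, read one bond further out, turns a (2-carboxyphenyl)amino group into a (4-methylpyridin-2-yl)amino group.

Going by the values given here, the step that bears on this is the one from compound 2 to compound 3, run in reverse: compound 2 carries a pyridin-2-yl group, and its result 100% stood well above compound 3. Compound 4 is therefore expected to sit near the top of the range, with an estimated value of 97% (between 85% and 100%). The expected step is a number 13.4 percentage points higher from compound 3 to compound 4 (beyond the scatter).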

Compound 4, oral bioavailability: 100%
Beside the measured number, compound 4's estimate is 3 percentage points below it, within the range that was stated.
By their numbers in this assay, from the lowest: compounds 3 and 1 (each within the scatter of the next); then compounds 2 and 4 (each within the scatter of the next).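

Adding a methyl on an aromatic carbon of the pyridin-2-yl group leaves the read-out in this assay without a step that stands out of the scatter (no change at the digits printed from compound 2 to compound 4 (within the scatter)), so the sulfonamide nitrogen can carry this larger ring group with the number kept level with that of compound 2. The 4-methylpyridin-2-yl group also stands clear of both phenyl groups (a number 16.4 percentage points higher from compound 3 to compound 4 (beyond the scatter); a number 14.4 percentage points higher from compound 1 to compound 4 (beyond the scatter)), so the gap seen with pyridin-2-yl is found again with a second pyridine-type group. No evidence at hand accounts for these steps.

Going by these compounds, it remains open whether an amine, a methoxy group or a longer chain in place of the methyl would keep the number level with compound 2 as the methyl does. On these data alone, it is equally open what a carboxylic acid on the pyridin-2-yl group would do to that number.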